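The source may report more compounds than this note shows. Statements on the series, on what has been measured and on what is new or still open speak of the compounds shown alone.

Of the compounds shown here, three have been tested in a functional assay on aorta (Rattus norvegicus, strain Sprague-Dawley) for inhibition, with a stated time of 20 min; a lower number here means a smaller maximal response, a higher number a larger maximal response. Compound 1 `C=CCc1cc(O)cc(C(=O)/C=C/c2ccc(O)cc2)c1O` gives 59.8%, compound 2 `O=C1CC(c2cccc(Br)c2)Oc2cc(O)cc(O)c21` gives 93.5%, and compound 3 `C=CCc1c(O)cc(O)c2c1OC(c1cccc(Cl)c1)CC2=O` gives 76.7%. Among these three numbers compound 3 stands second highest: compound 2 lies higher by a margin beyond the usual scatter, and compound 1 lies lower by a margin also beyond the scatter.

Compound 4 `C=CCc1c(O)cc(O)c2c1OC(c1ccc(O)cc1)CC2=O` has not yet been measured. It differs from compound 3 in one place: 4-hydroxyphenyl in place of 3-chlorophenyl on a saturated ring carbon. Among the measured compounds shown here, no pair of measured compounds shows this change by itself, so its size is not known from the data. Compound 1 also carries a 4-hydroxyphenyl and gives 59.8%, a lower number than compound 3, though on a different core. The step of a number 8.7 percentage points lower from compound 3 to compound 4 (within the scatter) is expected to be a modest decrease, possibly within the scatter. Compound 4 is expected to reach 68%, in the range 50% to 88%.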

Compound 4, largest response reached (Emax), in percent of the reference or control that the assay uses: 9.86%
Estimate against measurement, compound 4: 58.1 percentage points above; measured number below the stated range.
By their numbers in this assay, from the lowest: compound 4; then compound 1; then compound 3; then compound 2.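

Putting 4-hydroxyphenyl in place of 3-chlorophenyl on this saturated ring carbon, next to the ring oxygen, gives a number 66.8 percentage points lower from compound 3 to compound 4 (beyond the scatter) in this assay. Among the compounds shown here, this is the first single-place change in the set, and it shows that the group at this position can strongly set the maximal response on the shared core. Nothing available explains the size of this step.

Still open, as far as these compounds go, is whether the step follows the gain of the hydroxyl or the loss of the chlorine. Also open, from the compounds shown here alone, is how a plain phenyl or a 4-aminophenyl would read at this position.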